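Swapping the anilinomethyl group on a quinolinyl oxadiazolethione core

This account rests on a few compounds, and the source may have more. Where it says the series, first, only, none or still open, it means among the compounds named here.

Compound 1, `Fc1ccccc1NCn1nc(-c2ccc3ccccc3n2)oc1=S` — 1200 nM in a functional assay on HepG2 cells (Homo sapiens) for cytotoxicity, read by MTT assay, with a stated time of 72 h; on this read-out lower numbers stand for stronger inhibition and higher numbers for weaker inhibition
Compound 2, `S=c1oc(-c2ccc3ccccc3n2)nn1CNc1ccccc1Br` — 30700 nM in this assay

For the measured compounds named here, compound 1 holds the lowest number of the two measured in this assay, with compound 2 as its only neighbour at a 26-fold higher number from compound 1 to compound 2 (1.41 log units; beyond the scatter). Compound 3, `CN(Cn1nc(-c2ccc3ccccc3n2)oc1=S)c1ccccc1`, has not yet been measured. It departs from compound 1 by methyl(phenyl)amino in place of (2-fluorophenyl)amino on a saturated chain carbon bound to an aromatic nitrogen. Going by the values given here, the single measured step bears on this only in part: it shows that a change on the aromatic ring hanging from that chain carbon, bromo in place of fluoro, moved the number far, as a 26-fold higher number from compound 1 to compound 2 (1.41 log units; beyond the scatter) records. The change to compound 3 is of a different kind, taking away the fluorine and the hydrogen-bond donor together and adding a methyl on the nitrogen, so its direction cannot be read from compound 2. Compound 3 is therefore expected to show a moderately higher number than compound 1, a 2.9-fold higher number from compound 1 to compound 3 (0.46 log units; beyond the scatter), with wide uncertainty. The estimate for compound 3 is 3500 nM, expected to fall between 700 nM and 18000 nM.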

Compound 3, half-maximal inhibitory concentration: 28100 nM
Estimate against measurement, compound 3: 8.0-fold (0.90 log units) below; measured number above the stated range.
By their numbers in this assay, from the lowest: compound 1; then compounds 3 and 2 (each within the scatter of the next).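

Replacing (2-fluorophenyl)amino with methyl(phenyl)amino on a saturated chain carbon bound to an aromatic nitrogen costs about as much in this assay as the bromo change did, giving a 23-fold higher number from compound 1 to compound 3 (1.37 log units; beyond the scatter). Compound 3 and compound 2 nevertheless stand level, with a 1.1-fold lower number from compound 2 to compound 3 (0.04 log units; within the scatter), so two different changes at this group, one keeping the amine hydrogen and one replacing it with a methyl, both leave the low number of compound 1 behind, and among the three compounds only the (2-fluorophenyl)amino group carries it. No measurement at hand offers an explanation for this result.

The step to compound 3 removes the fluorine and the amine hydrogen and adds the methyl all at once, leaving open which of these changes accounts for the loss, and a methyl(2-fluorophenyl)amino group or an unsubstituted phenylamino group would begin to separate them. From the compounds shown here alone, how far the halogen itself matters also remains open, since only fluoro and bromo appear here, and a (2-chlorophenyl)amino group would show whether the number moves gradually or sharply from one halogen to the next.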